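Shortening the Ketone Chain of a Glutamate Receptor Modulator

The source may report more compounds than this note shows. Statements on the series, on what has been measured and on what is new or still open speak of the compounds shown alone.

Compound 1 `Cc1cc(C(=O)O)ccc1OCCCCOc1ccc(C(=O)CC(C)C)c(O)c1C`: 192 nM
Compound 2 `Cc1c(OCCCCOc2ccc(C(=O)O)cc2Cl)ccc(C(=O)CC(C)C)c1O`: 96 nM
Compound 3 `Cc1c(OCCCCOc2cccc(C(=O)O)c2)ccc(C(=O)CC(C)C)c1O`: 222 nM

In an assay on HEK293 cells for positive allosteric modulation of metabotropic glutamate receptor 2 (Rattus norvegicus), read by thallium flux, with a stated time of 2.5 min (on this read-out higher numbers stand for an effect only at larger amounts of compound and lower numbers for an effect already at smaller amounts), compound 1 stands second highest of the three numbers. Its nearest neighbour is a 1.2-fold higher number from compound 1 to compound 3 (0.06 log units; within the scatter), its furthest is a 2.0-fold lower number from compound 1 to compound 2 (0.30 log units; within the scatter). Compound 4 `CCC(=O)c1ccc(OCCCCOc2ccc(C(=O)O)cc2C)c(C)c1O` differs from compound 1 by methyl in place of isopropyl on a saturated chain carbon bound to a carbonyl carbon; cut one bond further out, isobutylcarbonyl becomes propanoyl. Among the compounds with values here, none of the measured steps touches this part of the molecule: all three change the substituted carboxyphenyl end, and the largest of them, a 2.3-fold higher number from compound 2 to compound 3 (0.36 log units; beyond the scatter), is only modest. Within the data shown here, no measured step therefore bears on the ketone change, and compound 4 is expected to show no step beyond the scatter, a 1.3-fold higher number from compound 1 to compound 4 (0.11 log units; within the scatter). The estimate for compound 4 is 250 nM, within a broad range from 80 nM to 800 nM.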

Compound 4, half-maximal effective concentration: 82 nM
Beside the measured number, compound 4's estimate is 3.0-fold (0.48 log units) above it, and the stated range covers the measured number.
By their numbers in this assay, from the lowest: compounds 4, 2, 1 and 3 (each within the scatter of the next, the first and the last beyond it).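

The ketone chain is no silent part of the molecule: in this assay, methyl in place of isopropyl on a saturated chain carbon bound to a carbonyl carbon gives a 2.3-fold lower number from compound 1 to compound 4 (0.37 log units; beyond the scatter), a modest step and the only one shown at this position. The shorter propanoyl is therefore tolerated here, with three heavy atoms leaving and one entering. Nothing measured here accounts for this step. On these data alone, whether an acetyl, a longer chain or an amine at this position would follow the same direction remains open. So does whether propanoyl gives a similar step on the carboxyphenyl ends of compound 2 and compound 3.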